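Methoxy for dimethylamino on a chalcone-type core

A few compounds are considered here, and "the series" means these few. Any claim that something is new, unique, unknown or untested is made for them only; others in the source may bear on it.

Measured compounds:
compound 1 `CN(C)c1ccc(/C=C/C(=O)c2ccc(N(C)C)cc2O)cc1` — 12100 nM
compound 2 `CCN(CC)CCCOc1ccc(C(=O)/C=C/c2ccc(N(C)C)cc2)c(O)c1` — 4100 nM
compound 3 `CCN(CCCCOc1ccc(/C=C/C(=O)c2ccc(N(C)C)cc2O)cc1)Cc1ccccc1OC` — 4600 nM

In an assay on isolated protein for inhibition of Amine oxidase [flavin-containing] B (Homo sapiens) (a lower number here means a stronger inhibitor, a higher number a weaker inhibitor), compound 1 gives 12100 nM, the highest number of the three measured compounds. Compound 3 gives 4600 nM in this assay, and compound 2 gives 4100 nM, both lower than compound 1 by more than the scatter.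

Compound 4 `COc1ccc(/C=C/C(=O)c2ccc(N(C)C)cc2O)cc1` has not been measured. It differs from compound 1 in one place: methoxy in place of dimethylamino on an aromatic carbon. For the measured compounds named here, only one directly comparable step is known, a 3.0-fold lower number from compound 1 to compound 2 (0.47 log units; beyond the scatter); that change sits on the other aromatic ring and replaces the same leaving group with a far larger alkoxy chain, so it bears on the present change only loosely. Compound 3, which carries a large alkoxy chain at the position changed here, shows a lower number than compound 1, but again with a much larger entering group than methoxy. Going by the values given here, the replacement of dimethylamino by methoxy is a small change of one neutral acceptor group for another, and no measured step tests it directly. Compound 4 is therefore expected to stay close to compound 1, with a step of a 1.3-fold lower number from compound 1 to compound 4 (0.13 log units; within the scatter), and its estimated value in this assay is 9000 nM with a range from 2500 nM to 30000 nM.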

Compound 4, half-maximal inhibitory concentration: 13300 nM
The estimate for compound 4 lay 1.5-fold (0.17 log units) below the measured number; measured number inside the range.
By their numbers in this assay, from the lowest: compounds 2 and 3 (each within the scatter of the next); then compounds 1 and 4 (each within the scatter of the next).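

In this assay, the change to methoxy at this position, on an aromatic carbon para to a large group, gives a 1.1-fold higher number from compound 1 to compound 4 (0.04 log units; within the scatter), so at this position dimethylamino and methoxy cannot be told apart. For the compounds shown here, this is the first direct reading of a small group at this position, whereas the earlier compounds offered only a large chain here or a change on the other ring. It also shows that a small oxygen-linked group does not reproduce the lower number of the larger chain: compound 4 gives 13300 nM, while compound 3, with its long amine-bearing alkoxy chain at the same position, gives 4600 nM. No measured evidence here explains why these two groups read alike.

The compounds shown leave open which part of the chain in compound 3 goes with its lower number, the length of the alkoxy chain or the tertiary amine and benzyl group at its end. They also leave open whether a plain butoxy chain, a hydroxyl or a chlorine at this position would stay level with methoxy.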